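This account rests on a few compounds, and the source may have more. Where it says the series, first, only, none or still open, it means among the compounds named here.

Three compounds share one core and differ only in the group carried by the outer phenyl ring. Compound 1 `CS(=O)(=O)c1ccc(-c2nc3ccccn3c2Sc2ccccc2)cc1` gives 70600 nM in a functional assay on HeLa cells (Homo sapiens) for inhibition, read by MTT assay, with a stated time of 48 h (a higher number here means a weaker inhibitor, a lower number a stronger inhibitor), the higher of the two numbers recorded. Compound 3 `N#Cc1ccc(-c2nc3ccccn3c2Sc2ccccc2)cc1` gives 64200 nM in this assay, and the step of a 1.1-fold lower number from compound 1 to compound 3 (0.04 log units; within the scatter) lies within the scatter. Compound 2 `COc1ccc(-c2nc3ccccn3c2Sc2ccccc2)cc1` gives > 100000 nM in this assay, which is a limit of the assay and not a number. That value is the limit of > 100000 nM in this assay, at which 1 of the 3 values shown sits.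

Compound 4 `CS(=O)(=O)c1ccc(-c2nc3ccccn3c2Sc2cccc3ccccc23)cc1` keeps the methylsulfonyl group of compound 1 and alters the other side: naphthalen-1-yl in place of phenyl on a sulfur. For the measured compounds named here, none of the measured steps touch this sulfur-bound ring, so they offer no guide, and no step beyond the scatter is expected in this assay. Compound 4 is estimated at 55000 nM, between 15000 nM and 100000 nM, a step of a 1.3-fold lower number from compound 1 to compound 4 (0.11 log units; within the scatter).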

Compound 4, half-maximal inhibitory concentration: 34600 nM
The estimate for compound 4 lay 1.6-fold (0.20 log units) above the measured number; low and high end bracket the measured number.
By their numbers in this assay, from the lowest: compounds 4, 3 and 1 (each within the scatter of the next, the first and the last beyond it). At a limit, above all of these: compound 2.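

Swapping the sulfur-bound phenyl for naphthalen-1-yl gives a 2.0-fold lower number from compound 1 to compound 4 (0.31 log units; beyond the scatter) in this assay. This modest step is the first shown to clear the scatter, so the ring on the sulfur can shift this number, and a second aromatic ring is accepted there. No measurement shown here explains the change. The compounds shown leave open whether the same swap would do the same with the nitrile of compound 3 in place of methylsulfonyl. They also leave open how a methyl group or a pyridine ring on the sulfur would compare.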